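Ret kinase series: N-substituent change on the core

The source may report more compounds than this note shows. Statements on the series, on what has been measured and on what is new or still open speak of the compounds shown alone.

Measured so far:
compound 1 `Nc1ncnc2c1c(-c1cc(C3CC3)on1)nn2C1CCOCC1` — 440 nM
compound 2 `CC(C)n1nc(-c2ccon2)c2c(N)ncnc21` — 3210 nM

In an assay on BaF3 cells for inhibition of proto-oncogene tyrosine-protein kinase receptor Ret (Homo sapiens), read by MTT assay, with a stated time of 48 h (on this read-out higher numbers stand for weaker inhibition of growth and lower numbers for stronger inhibition of growth), compound 1 gives 440 nM, the lowest of the two numbers in hand. Compound 2 gives 3210 nM in this assay, a gap that lies beyond the scatter. Within the data shown here, no pair of measured compounds differs in a single place, so no measured step is available to calibrate the change under consideration.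

Compound 3 `Cn1nc(-c2cc(C3CC3)on2)c2c(N)ncnc21` is not yet measured. It differs from compound 1 as follows: methyl in place of oxan-4-yl on an aromatic nitrogen. The expectation for compound 3 is a step from compound 1 of a 3.4-fold higher number from compound 1 to compound 3 (0.53 log units; beyond the scatter), toward a higher number, and most likely beyond the scatter, since compound 1 carries the lowest number seen and the oxan-4-yl group is exchanged for the far smaller methyl. For compound 3 the estimate in this assay is 1500 nM, with a range from 450 nM to 5000 nM.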

Compound 3, concentration for 50% growth inhibition: 2670 nM
The estimate for compound 3 lay 1.8-fold (0.25 log units) below the measured number; the range from low to high includes it.
By their numbers in this assay, from the lowest: compound 1; then compounds 3 and 2 (each within the scatter of the next).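

In this assay, among these compounds, methyl in place of oxan-4-yl on the aromatic nitrogen gives a 6.1-fold higher number from compound 1 to compound 3 (0.78 log units; beyond the scatter) and is the first step that isolates this position. With the 5-cyclopropyl-1,2-oxazol-3-yl group held constant, the position is not indifferent to its substituent: the lower number goes with oxan-4-yl and the higher number with methyl. No measurement at hand bears on why the number moves.

This single pair leaves open whether the step follows the ring as a whole or its oxygen, a question that a cyclohexyl group would help to separate. As far as these compounds go, how an amine such as piperidin-4-yl or a longer chain such as n-butyl would compare with oxan-4-yl here also remains open.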